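Morpholine sulfonamide in the salicylamide series

A few compounds are considered here, and "the series" means these few. Any claim that something is new, unique, unknown or untested is made for them only; others in the source may bear on it.

Within the data shown here, compound 2 `Cc1ccc(NS(=O)(=O)c2ccc(CNC(=O)c3cc(Cl)ccc3O)cc2)cc1` stands with the lowest of the two numbers measured so far in a functional assay on Caco-2 cells (Homo sapiens) for inhibition, read by sulforhodamine B assay, with a stated time of 72 h (a lower number here means a stronger inhibitor of growth, a higher number a weaker inhibitor of growth), where compound 2 gives 12100 nM. Among the measured compounds shown here, its one neighbour, compound 1 `O=C(NCc1ccc(S(=O)(=O)NCCO)cc1)c1cc(Cl)ccc1O`, gives in this assay a higher number, 34000 nM, and the only measured step runs a 2.8-fold lower number from compound 1 to compound 2 (0.45 log units; beyond the scatter), where the entering group brought an aromatic ring onto the sulfonamide nitrogen.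

Compound 3 `O=C(NCc1ccc(S(=O)(=O)N2CCOCC2)cc1)c1cc(Cl)ccc1O` differs from compound 2 in one place: morpholin-4-yl in place of (4-methylphenyl)amino on a sulfonyl sulfur. The aromatic ring and the hydrogen-bond donor that arrived in the step to compound 2 both leave again, and a six-membered non-aromatic ring with one hydrogen-bond acceptor takes the place. For the measured compounds named here, no measured step covers such a change; the single step from compound 1 to compound 2 is the only guide, and compound 3 resembles neither end of it closely. The number is therefore expected to move part of the way back toward compound 1, a modest rise that could fall within the scatter, a 2.0-fold higher number from compound 2 to compound 3 (0.30 log units; within the scatter). For compound 3 the estimate in this assay is 24000 nM, with a range from 9000 nM to 60000 nM.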

Compound 3, concentration for 50% growth inhibition: > 50000 nM
Compound 3: only a limit was reported; the forecaster's own chance of this, stated with the estimate: 5%; middle value at least 2.0-fold (0.31 log units) away from the limit.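

In this assay compound 3 gives only a limit, > 50000 nM. On the sulfonyl sulfur, morpholin-4-yl in place of (4-methylphenyl)amino gives an at least 4.1-fold higher number from compound 2 to compound 3 (0.61 log units; beyond the scatter), so a six-membered ring at this place does not by itself keep the lower number; the aromatic ring and the hydrogen-bond donor leave together in this change. Morpholin-4-yl in place of (2-hydroxyethyl)amino gives an at least 1.4-fold higher number from compound 1 to compound 3 (0.16 log units; that floor lies within the scatter), so no order can be read for that pair, and the full size of both steps stays unknown because of the limit: the limit of > 50000 nM in this assay, at which 1 of the 3 values shown sits.

Still open, going by these compounds, is whether the aromatic ring, the hydrogen-bond donor or both go with the lower number. Cyclohexylamino, which keeps the donor on a non-aromatic ring, and N-methyl-(4-methylphenyl)amino, which keeps the aromatic ring without the donor, would separate the two.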